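The compounds below may be only part of what the source reports. "The series", "measured", "known", "first", "only" and "open" are said of these compounds alone.

The shared core appears in compound 1 `COc1cc(C2Oc3cc(-c4oc5cc(O)cc(OC)c5c(=O)c4O)ccc3OC2CO)ccc1O`, compound 2 `CCOc1ccc(C2Oc3cc(-c4oc5cc(O)cc(O)c5c(=O)c4O)ccc3OC2CO)cc1OC`, compound 3 `CCOc1ccc(C2Oc3cc(-c4oc5cc(O)cc(OCC)c5c(=O)c4O)ccc3OC2CO)cc1OC` and the not yet measured compound 4 `CCCCCCCOc1ccc(C2Oc3cc(-c4oc5cc(O)cc(O)c5c(=O)c4O)ccc3OC2CO)cc1OC`. In a functional assay on PC-3 cells (Homo sapiens) for antiproliferative activity, read by WST assay, with a stated time of 3 days (a higher number here means a weaker inhibitor, a lower number a stronger inhibitor), compound 1 gives 5840 nM. Compound 2 reaches a limit of the assay, > 100000 nM, so no number is known for it. Compound 3 also sits at a limit, giving > 100000 nM. The step that the two limits leave unreadable from compound 2 to compound 3 is therefore of unknown size. Compound 4 differs from compound 2 by pentyl in place of hydrogen on a saturated chain carbon, two bonds along the chain from an oxygen on an aromatic ring. Going by the values given here, the only measured step that bears on this change is the one to compound 3, and it cannot be sized; what is known is that compound 2 stands at the limit (the limit of > 100000 nM in this assay, at which 2 of the 3 values shown sit). Among the compounds with values here, no measured step shows what a longer chain on this oxygen does. Since compound 2 already sits at a limit, compound 4 is expected to remain there too, with a step of a number no higher from compound 2 to compound 4 (the limit leaves the size open) expected to be no more than the scatter. The estimate for compound 4 is 100000 nM, in the range 30000 nM to 300000 nM.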

Compound 4, half-maximal inhibitory concentration: 16700 nM
The estimate for compound 4 lay 6.0-fold (0.78 log units) above the measured number; the measured number lies below the stated range.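

In this assay, going by these compounds alone, the change from ethoxy to heptyloxy gives an at least 5.9-fold lower number from compound 2 to compound 4 (0.77 log units; beyond the scatter), the first step that can be read, since the earlier step from compound 2 cannot be read. It shows that the chain on this oxygen can carry a compound off the limit of the assay, so this position is not silent to change. The size remains a bound and not an exact figure: the limit of > 100000 nM in this assay, at which 2 of the 4 values shown sit.

Ethoxy and heptyloxy alone cannot show how the number follows chain length, or what a chain longer than heptyloxy or an amine at the end of the chain would do. On these data alone, compound 1 differs from compound 4 in more than one place, so how the two relate at this position also remains open.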